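The compounds below may be only part of what the source reports. "The series", "measured", "known", "first", "only" and "open" are said of these compounds alone.

Compound 1 `CNC(=O)C1CCN(c2ccc(Cl)c(C(F)(F)F)c2)C1`: 1300 nM
Compound 2 `O=C(Nc1ccccc1)C1CCN(c2ccc(Cl)c(C(F)(F)F)c2)C1`: 1000 nM
Compound 3 `CN1CN(C(=O)C2CCN(c3ccc(Cl)c(C(F)(F)F)c3)C2)CC1=O`: 1400 nM

These half-maximal inhibitory concentrations come from an assay on cells for inhibition of Palmitoleoyl-protein carboxylesterase NOTUM variant C330S (Homo sapiens), read by fluorescence, with a stated time of 40 min; on this read-out higher numbers stand for weaker inhibition and lower numbers for stronger inhibition. Compound 1 stands second highest of the three numbers, with compound 3 nearest and compound 2 furthest; the steps of a 1.3-fold lower number from compound 1 to compound 2 (0.11 log units; within the scatter) and a 1.1-fold higher number from compound 1 to compound 3 (0.03 log units; within the scatter) both lie within the scatter, as does a 1.4-fold higher number from compound 2 to compound 3 (0.15 log units; within the scatter). Compound 4 `FC(F)(F)c1cc(N2CCC(c3nnco3)C2)ccc1Cl` differs from compound 1 by 1,3,4-oxadiazol-2-yl in place of methylcarbamoyl on a saturated ring carbon. Going by the values given here, no measured step exchanges the methylcarbamoyl group for an aromatic ring of this kind; the three steps only vary what sits on the carbonyl carbon or the amide nitrogen, and none of them moved the number beyond the scatter. On that basis the change from compound 1 to compound 4 is expected to be small, a 1.1-fold lower number from compound 1 to compound 4 (0.03 log units; within the scatter). Compound 4 is therefore estimated at 1200 nM, within a range of 400 nM to 3600 nM.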

Compound 4, half-maximal inhibitory concentration: 24000 nM
Compound 4: the middle estimate sits 20-fold (1.30 log units) below what was measured; measured number above the stated range.
By their numbers in this assay, from the lowest: compounds 2, 1 and 3 (each within the scatter of the next); then compound 4.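

In this assay, the saturated ring carbon proved sensitive to what it carries: 1,3,4-oxadiazol-2-yl in place of methylcarbamoyl gave an 18-fold higher number from compound 1 to compound 4 (1.27 log units; beyond the scatter), whereas the earlier changes on the carbonyl carbon and the amide nitrogen all stayed within the scatter. So the carbonyl-linked group tolerated variation beyond its carbonyl, but this five-membered aromatic ring was not an equivalent replacement for it. Nothing available explains this step. The compounds shown leave open whether the amide hydrogen or the carbonyl is the part that counts, and how a carboxylic acid or an aminomethyl group on this carbon would compare.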